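Amino in Place of Chloro: Compound 3 to Compound 4

The source may hold more compounds than are shown below. What is called first, only, known or untested is meant among the compounds shown, and "the series" means these compounds.

Compound 3 `ClCc1cccc(Cn2cnc3c(Cl)nc(Cl)nc32)c1` gives in a functional assay on HT-29 cells (Homo sapiens) for cytotoxicity, read by sulforhodamine B assay, with a stated time of 48 h (a lower number here means a stronger inhibitor of growth, a higher number a weaker inhibitor of growth), only a limit, > 100000 nM. Compound 1 `ClCc1cccc(Cn2cnc3c(Cl)ncnc32)c1` likewise reaches only the limit of > 100000 nM. Compound 2 `ClCc1ccc(Cn2cnc3nc(Cl)nc(Cl)c32)cc1` also sits at the limit, > 100000 nM. Within the data shown here, the one step between measured compounds, a step that the two limits leave unreadable from compound 1 to compound 3, is therefore unreadable, and the three values together show (the limit of > 100000 nM in this assay, at which 3 of the 3 values shown sit). Compound 4 `Nc1nc(Cl)c2ncn(Cc3cccc(CCl)c3)c2n1` differs from compound 3 by amino in place of chloro on an aromatic carbon. Among the measured compounds shown here, no measured step tells what an amino group does here, so nothing beyond the scatter can be expected in either direction, and the most likely outcome is that this assay again reports only a limit. Compound 4 is therefore estimated at 100000 nM, between 30000 nM and 300000 nM. The step expected from this is a number no higher from compound 3 to compound 4 (the limit leaves the size open).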

Compound 4, concentration for total growth inhibition: 9770 nM
Compound 4: the middle estimate sits 10-fold (1.01 log units) above what was measured, outside the stated range (below it).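

Amino on this aromatic carbon, between two ring nitrogen atoms, brings an at least 10-fold lower number from compound 3 to compound 4 (1.01 log units; beyond the scatter) in this assay and so gives the first value shown that is not a limit. Set against hydrogen at the same place, it brings an at least 10-fold lower number from compound 1 to compound 4 (1.01 log units; beyond the scatter), so at this position amino stands apart from both chloro and hydrogen. The earlier compounds shown here showed no difference of any size, only this: the limit of > 100000 nM in this assay, at which 3 of the 4 values shown sit.

Going by these compounds, whether a methylamino or hydroxyl group at this position would do the same remains open. So does whether the chloromethyl group is needed for the growth inhibition seen with amino.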